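The source may report more compounds than this note shows. Statements on the series, on what has been measured and on what is new or still open speak of the compounds shown alone.

Measured compounds:
Compound 1, `O=C(COc1ccc2c(=O)ccoc2c1)Nc1cccc(NC(=O)c2ccccc2)c1`: 16 nM
Compound 2, `Cc1ccc(C(=O)Nc2cccc(NC(=O)COc3ccc4c(=O)ccoc4c3)c2)cc1`: 22 nM
Compound 3, `CN(C)c1ccc(C(=O)Nc2ccc(NC(=O)COc3ccc4c(=O)ccoc4c3)cc2)cc1`: 302 nM

All three were tested in an assay on isolated protein for inhibition of Rho-associated protein kinase 2 (Homo sapiens), read by scintillation counting, radiometric assay and 33P incorporation, with a stated time of 40 min, in the presence of a further agent that is not named here; a lower number here means a stronger inhibitor, a higher number a weaker inhibitor. Compound 1 and compound 2 share a core and differ only in one place: methyl in place of hydrogen on an aromatic carbon. That change gave a 1.4-fold higher number from compound 1 to compound 2 (0.14 log units; within the scatter). Compound 3 carries a different arrangement; the difference between its core and the core of compound 1 is not broken down here. In this assay compound 3 gives a number higher than both compound 2 and compound 1, and in each case the gap lies beyond the scatter.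

Compound 4, `Cc1cc(NC(=O)COc2ccc3c(=O)ccoc3c2)ccc1NC(=O)c1ccc(N(C)C)cc1`, has not been measured. It differs from compound 3 by methyl in place of hydrogen on an aromatic carbon. Among the measured compounds shown here, this is the same kind of change as the one from compound 1 to compound 2, not the same: there the methyl sat para to a large group, here it sits ortho to a large group and meta to a large group.

Compound 4 is expected to give about 320 nM, most likely between 130 nM and 800 nM. This expectation means a step of a 1.1-fold higher number from compound 3 to compound 4 (0.03 log units; within the scatter), and it rests on the earlier step of a 1.4-fold higher number from compound 1 to compound 2 (0.14 log units; within the scatter) together with compound 3 at 302 nM.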

Compound 4, half-maximal inhibitory concentration: 4210 nM
Beside the measured number, compound 4's estimate is 13-fold (1.12 log units) below it; the whole stated range lies below it.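

In this assay, methyl in place of hydrogen on an aromatic carbon gave a 14-fold higher number from compound 3 to compound 4 (1.14 log units; beyond the scatter), a large loss of inhibition. Set beside the earlier step, the same kind of change did not carry over in size from one core to the other: the same change on two cores in this assay, a 1.4-fold higher number (0.14 log units; within the scatter) from compound 1 to compound 2 and a 14-fold higher number (1.14 log units; beyond the scatter) from compound 3 to compound 4, 10-fold (1.01 log units) apart, beyond the scatter of two such steps. This shows that a step read on one core cannot simply be transferred to the other in this series, but it does not show what separates the two cases, as the pairs differ both in the core and in where the methyl sits, and compound 4 has it ortho to a large group and meta to a large group.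

The compounds shown leave open whether the methyl would give a similarly large step at this place on the core of compound 1, and whether the dimethylamino group of compound 3 has any part in the result. They also leave open whether a fluorine atom or a methoxy group at the same place would behave as the methyl does.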